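A few compounds are considered here, and "the series" means these few. Any claim that something is new, unique, unknown or untested is made for them only; others in the source may bear on it.

Compound 1 `COc1cc(NCc2ccccc2)cc(OC)c1OC` and compound 2 `COc1ccc(CNc2cc(OC)c(OC)c(OC)c2)cc1Cl` share a trimethoxyphenyl-amine core with compound 3 `CCC/C=C/C(=O)N(Cc1ccc(OC)c(O)c1)c1cc(OC)c(OC)c(OC)c1`. In a functional assay on KYSE-450 cells (Homo sapiens) for inhibition, read by MTT assay, with a stated time of 48 h (a higher number here means a weaker inhibitor, a lower number a stronger inhibitor), compound 1 gives only a limit, > 80000 nM. Compound 2 gives 47800 nM in this assay. Compound 3, which carries an additional amide on the nitrogen, gives 57 nM, the lowest of the two numbers, and compound 2 sits higher by a gap beyond the scatter. Compound 4 `COc1ccc(CN(C(=O)C[Se]C#N)c2cc(OC)c(OC)c(OC)c2)cc1O` differs from compound 3 only on the carbonyl carbon, where (a group of 4 heavy atoms (2 carbon, 1 nitrogen, 1 selenium; no ring) in place of a group of 5 heavy atoms (5 carbon; no ring), on a carbonyl carbon). Going by the values given here, no step between measured compounds covers this kind of change. Compound 4 is expected to remain in the same region as compound 3, with a modest loss at most, a step of a 2.6-fold higher number from compound 3 to compound 4 (0.42 log units; beyond the scatter). Compound 4 is therefore estimated at 150 nM, between 30 nM and 800 nM.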

Compound 4, half-maximal inhibitory concentration: 280 nM
The estimate for compound 4 lay 1.9-fold (0.27 log units) below the measured number; the measured number falls inside the stated range.
By their numbers in this assay, from the lowest: compound 3; then compound 4; then compound 2. At a limit, above all of these: compound 1.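

At the carbonyl carbon, exchanging pent-1-en-1-yl for the group of 4 heavy atoms that carries selenium and a nitrile gives, in this assay, a 4.9-fold higher number from compound 3 to compound 4 (0.69 log units; beyond the scatter). Going by these compounds alone, this is the first step read at this position, and it shows that the change costs only modestly. Nothing measured here gives a reason for this step. On these data alone, it stays open whether the selenium, the nitrile or the lost double bond accounts for the difference, and how an amine, a carboxylic acid or a longer chain on that carbonyl carbon would read.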